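The source may report more compounds than this note shows. Statements on the series, on what has been measured and on what is new or still open speak of the compounds shown alone.

Of the compounds shown here, three have been measured so far, all built on the same core and differing only in the groups at its ends. Compound 1 `COc1cccc(Oc2ccc3c(NCCCNCc4cc(F)ccc4OC)ccnc3c2)c1` gives 317 10^-6 cm/s in an ADME assay for permeability, using PAMPA, with a stated time of 30 min, at pH 7.4; a higher number here means that the compound crosses the layer faster, a lower number that the compound crosses the layer more slowly. Compound 2 `Fc1ccc(Oc2ccc3c(NCCCNCc4ccco4)ccnc3c2)cc1` gives 317 10^-6 cm/s in this assay. Compound 3 `COc1cccc(Oc2ccc3c(NCCCNCc4cccc(OC)c4O)ccnc3c2)c1` gives 317 10^-6 cm/s in this assay, so compound 3 stands level with compound 1 and compound 2 at the digits shown, with no measured compound set apart from the others beyond the scatter.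

Among the measured compounds shown here, only one measured pair differs in a single place, and that step, no change at the digits printed from compound 1 to compound 3 (within the scatter), concerned the group on the saturated chain carbon bound to the amine nitrogen.

Compound 4 `COc1cccc(CNCCCNc2ccnc3cc(Oc4ccc(C(C)(C)C)cc4)ccc23)c1O` is the next compound, not yet measured. It differs from compound 3 at another place: 4-(tert-butyl)phenyl in place of 3-methoxyphenyl on an oxygen on an aromatic ring. For the measured compounds named here, no measured step touches the group on this oxygen, so the only guide is the earlier step at a different end of the molecule, which stayed within the scatter, and the fact that all three measured compounds sit at one level. On that basis the step from compound 3 to compound 4 is expected to be no change at the digits printed from compound 3 to compound 4 (within the scatter), nothing beyond the scatter. Compound 4 is therefore estimated at 317 10^-6 cm/s in this assay, with a range from 180 10^-6 cm/s to 500 10^-6 cm/s.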

Compound 4, apparent permeability: 317 10^-6 cm/s
The estimate for compound 4 equals the measured number at the digits printed; the measured number falls inside the stated range.
By their numbers in this assay, from the lowest: compounds 1, 2, 3 and 4 (each within the scatter of the next).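

Among the compounds shown here, replacing 3-methoxyphenyl with 4-(tert-butyl)phenyl on an oxygen on an aromatic ring gives no change at the digits printed from compound 3 to compound 4 (within the scatter) in this assay and is the first measured step at this end of the molecule, since the earlier step concerned only the group on the saturated chain carbon bound to the amine nitrogen. The step is not a trivial edit on paper: the entering group has more heavy atoms, is made of carbon only and has no hydrogen-bond acceptor, whereas the leaving group has one, yet the reading stays within the scatter. Nothing measured here explains why this exchange leaves the reading where it was.

A single step at this place cannot show how other groups on the oxygen would behave, such as a phenyl ring carrying an amine or a carboxylic acid, nor whether a longer chain between the two nitrogens would behave the same way. As far as these compounds go, since all four compounds print the same number, it also remains open whether any change to this series can move the reading beyond the scatter.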